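Taking one chloro away from compound 2

A few compounds are considered here, and "the series" means these few. Any claim that something is new, unique, unknown or untested is made for them only; others in the source may bear on it.

In an ADME assay on J774 cells (Mus musculus) for cytotoxicity (on this read-out higher numbers stand for weaker inhibition and lower numbers for stronger inhibition), compound 1 (`CC1(C)[N+]([O-])=c2ccc(/C=N/O)cc2=[N+]1[O-]`) gives 77 uM and compound 2 (`CC1(C)[N+]([O-])=c2cc(Cl)c(Cl)cc2=[N+]1[O-]`) gives 100 uM and so sits within the scatter of compound 1. Compound 3 (`CC1(C)[N+]([O-])=c2ccc(Cl)cc2=[N+]1[O-]`) differs from compound 2 by hydrogen in place of chloro on an aromatic carbon of the shared core. Going by the values given here, no measured pair shows such a change, so the expectation is weakly grounded: no step beyond the scatter is expected in this assay in either direction. The expected step is a 1.1-fold lower number from compound 2 to compound 3 (0.05 log units; within the scatter) and remains an estimate. Compound 3 is expected at 90 uM with an estimated range from 40 uM to 200 uM in this measurement.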

Compound 3, concentration for 50% inhibition: 38 uM
The estimate for compound 3 lay 2.4-fold (0.37 log units) above the measured number; measured number outside the range, below it.
By their numbers in this assay, from the lowest: compound 3; then compounds 1 and 2 (each within the scatter of the next).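

In this assay, the chloro at this aromatic carbon, ortho to a chloro group, is not neutral: a 2.6-fold lower number from compound 2 to compound 3 (0.42 log units; beyond the scatter) follows when hydrogen takes its place. With one chlorine atom in place of a group of 3 heavy atoms, a 2.0-fold lower number from compound 1 to compound 3 (0.31 log units; beyond the scatter) also lies beyond the scatter, so compound 3 stands apart from both other compounds. Nothing available explains either step. The compounds shown leave open whether this carbon responds only to chloro, and what an amine or a carboxylic acid there would give.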